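The source may hold more compounds than are shown below. What is called first, only, known or untested is meant among the compounds shown, and "the series" means these compounds.

In a functional assay on A549 cells (Homo sapiens) for inhibition, read by MTT assay, with a stated time of 72 h (on this read-out higher numbers stand for weaker inhibition and lower numbers for stronger inhibition), compound 1 `Nc1ncnc2c1c(-c1cnc3[nH]ccc3c1)nn2CCCCCCCCC(=O)NO` gives 12300 nM. Compound 2 `Nc1ncnc2c1c(-c1cnc3[nH]ccc3c1)nn2CCCCCC(=O)NO` gives > 150000 nM, which is a limit of the assay and not a number. Compound 3 `Nc1ncnc2c1c(-c1cnc3[nH]ccc3c1)nn2CCCCCCC(=O)NO` gives 50000 nM, the higher of the two actual numbers in the series, with a 4.1-fold higher number from compound 1 to compound 3 (0.61 log units; beyond the scatter).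

Compound 4 `Nc1ncnc2c1c(-c1cnc3[nH]ccc3c1)nn2CCC(=O)NO` carries a further cut in the chain: hydroxycarbamoyl in place of 4-(hydroxycarbamoyl)butyl on a saturated chain carbon, two bonds along the chain from an aromatic nitrogen, (hydroxycarbamoyl in place of 4-(hydroxycarbamoyl)butyl on a saturated chain carbon, two bonds along the chain from an aromatic nitrogen).

The measured steps that bear on this all shorten or lengthen the same chain. Shortening gave an at least 12-fold higher number from compound 1 to compound 2 (1.08 log units; beyond the scatter), while lengthening gave an at least 3.0-fold lower number from compound 2 to compound 3 (0.47 log units; beyond the scatter), and all three compounds agree that the shorter chain has the higher number. The cut in compound 4 goes well past that of compound 2, so a large rise is expected in this assay, possibly one reported only as a limit. The expected step is a 3.6-fold higher number from compound 3 to compound 4 (0.56 log units; beyond the scatter). Compound 4 is estimated at 180000 nM, within a range of 70000 nM to 500000 nM.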

Compound 4, half-maximal inhibitory concentration: > 150000 nM
Compound 4: no number, only a limit (the forecaster's own chance of this, stated with the estimate: 60%); the middle value is on the limit's open side.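

In this assay compound 4 gives > 150000 nM, which is a limit of the assay and not a number, and the series now meets this limit a second time: the limit of > 150000 nM in this assay, at which 2 of the 4 values shown sit. Cutting 4-(hydroxycarbamoyl)butyl back to hydroxycarbamoyl gives an at least 3.0-fold higher number from compound 3 to compound 4 (0.47 log units; beyond the scatter), and the full span of the chains shown gives an at least 12-fold higher number from compound 1 to compound 4 (1.08 log units; beyond the scatter). The step between compound 2 and compound 4 cannot be read, since both values are limits, so the series shows no order among the shortest chains.

Going by these compounds, it remains open whether a longer chain than that of compound 1 would lower the number further. On these data alone, it is also open how a carboxylic acid or a primary amide in place of hydroxycarbamoyl would read at any of these chain lengths.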